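This account rests on a few compounds, and the source may have more. Where it says the series, first, only, none or still open, it means among the compounds named here.

In an assay on membranes from CHO cells for displacement of a labelled ligand from adenosine receptor A1 (Homo sapiens), read by scintillation counting, with a stated time of 60 min, tested at 1 uM (a higher number here means more inhibition at the concentration tested (going by the name of the read-out), a lower number less inhibition), three compounds of a shared core have been measured. Compound 1 `CC1=C(C(=O)CC(C)C)C(c2ccsc2)NC(=O)N1` gives 37%. Going by the values given here, compound 2 `CCNC(=O)C1=C(C)NC(=O)NC1c1ccsc1` gives 3%, and the one measured step, a number 34 percentage points lower from compound 1 to compound 2 (beyond the scatter), concerns ethylamino in place of isobutyl on a carbonyl carbon. Compound 3 `CCC(C)OC(=O)C1=C(C)NC(=O)NC1c1ccoc1` gives 13% in this assay, which stands second highest of the three numbers: compound 2 lies within the scatter of it, while compound 1 lies beyond the scatter above it.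

Compound 4 `CCC(C)OC(=O)C1=C(C)NC(=O)NC1c1ccsc1` differs from compound 3 by thiophen-3-yl in place of furan-3-yl on a saturated ring carbon. Among the compounds with values here, no measured step concerns this exchange of the five-membered aromatic ring: the step from compound 1 to compound 2 touches the group on the carbonyl carbon, not the ring on the saturated ring carbon, and compound 1 and compound 2 both carry thiophen-3-yl while compound 3 carries furan-3-yl with a different group on the carbonyl carbon. Compound 4 is therefore expected to sit near compound 3, with a step of a number 5 percentage points higher from compound 3 to compound 4 (within the scatter) in this assay that is expected to stay within the scatter. The estimate for compound 4 in this assay is 18%, expected to fall between 5% and 35%.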

Compound 4, a percentage reported as inhibition, at one concentration (the size of the read-out at that concentration, not a potency): 5%
Compound 4: the middle estimate sits 13 percentage points above what was measured; measured number inside the range.
By their numbers in this assay, from the lowest: compounds 2, 4 and 3 (each within the scatter of the next); then compound 1.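

In this assay, going by these compounds alone, the exchange on the saturated ring carbon can now be read for the first time: a number 8 percentage points lower from compound 3 to compound 4 (within the scatter) so with sec-butoxy on the carbonyl carbon, thiophen-3-yl and furan-3-yl cannot be told apart. With thiophen-3-yl held, a number 32 percentage points lower from compound 1 to compound 4 (beyond the scatter) and a number 2 percentage points higher from compound 2 to compound 4 (within the scatter) so sec-butoxy and ethylamino cannot be told apart, while isobutyl stands beyond the scatter from both. No measured evidence here gives a reason for these steps.

The compounds shown leave open whether a carboxylic acid or a longer chain on the carbonyl carbon, or phenyl in place of thiophen-3-yl on the saturated ring carbon, would stand with isobutyl or with the other two groups. They also leave open whether furan-3-yl and thiophen-3-yl stay level with isobutyl on the carbonyl carbon.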